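A few compounds are considered here, and "the series" means these few. Any claim that something is new, unique, unknown or untested is made for them only; others in the source may bear on it.

Four compounds built on one shared core were examined in a functional assay on PC-3 cells (Homo sapiens) for antiproliferative activity, read by MTT assay, with a stated time of 96 h; on this read-out higher numbers stand for weaker inhibition of growth and lower numbers for stronger inhibition of growth. Compound 1 `Oc1ccc(Cl)c2ccc(Sc3ccccn3)nc12` gives 10200 nM in this assay. Compound 2 `Oc1ccc(Br)c2ccc(Sc3ccccn3)nc12` differs from compound 1 in a single place, (bromo in place of chloro on an aromatic carbon), and in this assay compound 2 gives 10200 nM. The step of no change at the digits printed from compound 1 to compound 2 (within the scatter) is therefore flat, and no order between compound 1 and compound 2 can be read from these two numbers.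

Compound 3 `Oc1ccc(Cl)c2ccc(Oc3ccccn3)nc12` carries a different core; how its core differs from that of compound 1 is not broken down here. In this assay compound 3 gives only a limit, > 30000 nM, and not a number. This is the limit of the limit of > 30000 nM in this assay, at which 1 of the 3 values shown sits.

Compound 4 `Oc1ccc(Br)c2ccc(Oc3ccccn3)nc12` has not yet been measured in this assay. It stands to compound 3 as compound 2 stands to compound 1: the change is bromo in place of chloro on an aromatic carbon, and the place of the change is described word for word as for the pair of compound 1 and compound 2, so it is the same change. Compound 4 is expected to behave like compound 3, with an estimated step that the limit leaves unreadable from compound 3 to compound 4 in this assay; this expectation rests on the flat step no change at the digits printed from compound 1 to compound 2 (within the scatter) seen for the same change on the other core. Compound 4 is accordingly estimated at 45000 nM in this assay, with a likely range from 20000 nM to 150000 nM, and a reading that is again only a limit is thought more probable than a number.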

Compound 4, concentration for 50% growth inhibition: > 30000 nM
Compound 4: no number, only a limit (the forecaster's own chance of this, stated with the estimate: 80%); the middle value is on the limit's open side.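

In this assay compound 4 gives only a limit, > 30000 nM, not a number. Compound 3 is also held at a limit, and no step can be read between the two compounds: the limit of > 30000 nM in this assay, at which 2 of the 4 values shown sit. The compounds shown leave open whether bromo in place of chloro on the core of compound 3 alters growth inhibition at all, and, if it does, in which direction and by how much.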